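Swapping the pyridine for a fluorophenyl at the hydrazone

This account rests on a few compounds, and the source may have more. Where it says the series, first, only, none or still open, it means among the compounds named here.

Measured compounds:
- compound 1, `Cc1c(C(=O)N/N=C\c2cccc(O)c2O)oc2cccc(O)c12`: 12200 nM
- compound 2, `Cc1c(C(=O)N/N=C\c2cccc(O)c2)oc2cccc(O)c12`: 17600 nM
- compound 3, `Cc1c(C(=O)N/N=C\c2ccccn2)oc2cccc(O)c12`: >= 40000 nM

In a functional assay on PC-3 cells (Homo sapiens) for inhibition (a lower number here means a stronger inhibitor, a higher number a weaker inhibitor), compound 1 gives 12200 nM. The step of a 1.4-fold higher number from compound 1 to compound 2 (0.16 log units; within the scatter) leaves the two compounds indistinguishable. Compound 3 is different: in this assay it reaches only (the limit of >= 40000 nM in this assay, at which 1 of the 3 values shown sits), so its value is a limit rather than a number, and it is the weakest of the three. The steps of an at least 3.2-fold higher number from compound 1 to compound 3 (0.51 log units; beyond the scatter) and an at least 2.2-fold higher number from compound 2 to compound 3 (0.35 log units; beyond the scatter) show that the pyridine ring costs potency compared with either hydroxyphenyl ring.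

Compound 4, `Cc1c(C(=O)N/N=C\c2ccc(F)cc2)oc2cccc(O)c12`, is not yet measured. Its difference from compound 3 is 4-fluorophenyl in place of pyridin-2-yl on a carbon with a double bond to nitrogen. Among the measured compounds shown here, no measured step joins two rings that both lack a hydroxy group, so the closest guides are the steps from compound 1 and compound 2 to compound 3, which say only that losing the hydroxyls hurts. The fluorophenyl ring restores nothing of that kind. The expected step of an at least 1.3-fold lower number from compound 3 to compound 4 (0.12 log units; that floor lies within the scatter) is therefore small and uncertain. In this assay compound 4 is estimated at 30000 nM, within 12000 nM to 70000 nM.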

Compound 4, half-maximal inhibitory concentration: >= 40000 nM
Compound 4: only a limit was reported; the forecaster's own chance of this, stated with the estimate: 45%; middle value at least 1.3-fold (0.12 log units) away from the limit.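

In this assay, compound 4 ends at a limit rather than a number, as compound 3 does: the limit of >= 40000 nM in this assay, at which 2 of the 4 values shown sit.

The step between these two compounds cannot be read, so neither pyridin-2-yl nor 4-fluorophenyl can be ranked above the other at this carbon. What is new is that the poor result does not depend on the ring nitrogen of compound 3: a carbon-only ring without a hydroxy group also falls short of both hydroxyphenyl compounds, with an at least 2.2-fold higher number from compound 2 to compound 4 (0.35 log units; beyond the scatter) and an at least 3.2-fold higher number from compound 1 to compound 4 (0.51 log units; beyond the scatter).

As far as these compounds go, how much potency compound 3 and compound 4 retain remains unknown. From the compounds shown here alone, it is also open whether the hydroxy group is specifically needed, or whether a phenyl ring carrying an amine or a carboxylic acid would serve equally well on this carbon.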